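This account rests on a few compounds, and the source may have more. Where it says the series, first, only, none or still open, it means among the compounds named here.

Compound 2, `CCN(CC)c1ccc2nc(-c3ccccc3N(C)C)[nH]c(=O)c2c1`, is the one of the two measured compounds to look at first. Among the compounds with values here, in an assay on isolated protein for inhibition of DNA topoisomerase 1 (Homo sapiens), with a stated time of 30 min, tested at 100 uM (on this read-out lower numbers stand for a weaker effect and higher numbers for a stronger effect at the one concentration tested), compound 2 gives 82.1%, which places it at the top of the two numbers so far, yet only by a step that lies within the scatter: compound 1, `CCN(CC)c1ccc2nc(-c3ccccc3OC(F)(F)F)[nH]c(=O)c2c1`, gives 81.2% in this assay, and the step of a number 0.9 percentage points higher from compound 1 to compound 2 (within the scatter) is too small to tell the two apart.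

Compound 3, `CCN(CC)c1ccc2nc(-c3ccccc3C(F)(F)F)[nH]c(=O)c2c1`, is not yet measured. It differs from compound 2 in one place: trifluoromethyl in place of dimethylamino on an aromatic carbon. Within the data shown here, the only measured step that bears on this position is the one from compound 1 to compound 2, where trifluoromethoxy gave way to dimethylamino at the same aromatic carbon, and that step, a number 0.9 percentage points higher from compound 1 to compound 2 (within the scatter), stayed within the scatter. Two quite different groups at this place thus gave the same read-out, so the step to trifluoromethyl is expected to be a number 2.1 percentage points lower from compound 2 to compound 3 (within the scatter), with no change beyond the scatter. Compound 3 is therefore estimated to give 80% in this assay, with a range from 66% to 92%.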

Compound 3, a percentage reported as inhibition, at one concentration (the size of the read-out at that concentration, not a potency): 81.7%
Compound 3: the middle estimate sits 1.7 percentage points below what was measured; low and high end bracket the measured number.
By their numbers in this assay, from the lowest: compounds 1, 3 and 2 (each within the scatter of the next).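

With trifluoromethyl, this aromatic carbon, ortho to a large group, has now carried a third group in this assay, and the step is a number 0.4 percentage points lower from compound 2 to compound 3 (within the scatter), so replacing dimethylamino, which carries nitrogen, with trifluoromethyl, which carries fluorine, does not separate the two compounds. The comparison with the oxygen-linked group gives a number 0.5 percentage points higher from compound 1 to compound 3 (within the scatter), which shows that removing the oxygen between the ring and the trifluoromethyl unit also leaves the read-out within the scatter, so all three groups at this place are indistinguishable in this assay. No measurement is available that could explain why these groups give matching read-outs.

As far as these compounds go, it remains open whether a hydrogen, a carboxylic acid, a primary amine or a longer chain at this carbon would also stay within the scatter, or whether one of them would move the read-out beyond it. The read-out at one concentration also gives no potency, so the compounds shown leave open whether compound 1, compound 2 and compound 3 would still match across a range of concentrations.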